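A few compounds are considered here, and "the series" means these few. Any claim that something is new, unique, unknown or untested is made for them only; others in the source may bear on it.

Measured compounds in a functional assay on KYSE-450 cells (Homo sapiens) for inhibition, read by MTT assay, with a stated time of 48 h; on this read-out lower numbers stand for stronger inhibition and higher numbers for weaker inhibition:
- compound 1 `CCC/C=C/C(=O)N(Cc1ccc(OC)c(O)c1)c1cc(OC)c(OC)c(OC)c1`: compound 1 gives 57 nM
- compound 2 `C=CC(=O)N(Cc1ccc(OC)c(O)c1)c1cc(OC)c(OC)c(OC)c1`: compound 2 gives 160 nM

Within the data shown here, compound 2 stands at the higher of the two numbers; the only neighbour, compound 1, sits lower, and the one step between them, a 2.8-fold higher number from compound 1 to compound 2 (0.45 log units; beyond the scatter), is a modest change beyond the scatter that accompanies shortening the chain on the carbonyl carbon.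

Compound 3 `COc1ccc(CN(C(=O)C(C)C)c2cc(OC)c(OC)c(OC)c2)cc1O` is the next candidate. The change from compound 2 is isopropyl in place of vinyl on a carbonyl carbon. Among the measured compounds shown here, only the step from compound 1 to compound 2 bears on it, and only partly: it covers a change in chain length on the same carbonyl carbon, not the loss of the double bond outside aromatic rings, which no measured pair covers. For the measured compounds named here, the gain of one heavy atom on the carbonyl carbon would, by the one step, point towards a lower number, but the loss of the double bond has no precedent here, so on balance no step beyond the scatter is expected and the direction is uncertain.

Compound 3 is therefore estimated at 200 nM, range 70 nM to 600 nM, an expected step of a 1.3-fold higher number from compound 2 to compound 3 (0.10 log units; within the scatter).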

Compound 3, half-maximal inhibitory concentration: 390 nM
Beside the measured number, compound 3's estimate is 2.0-fold (0.29 log units) below it; the range from low to high includes it.
By their numbers in this assay, from the lowest: compound 1; then compound 2; then compound 3.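

In this assay isopropyl in place of vinyl on the carbonyl carbon gives a 2.4-fold higher number from compound 2 to compound 3 (0.39 log units; beyond the scatter) and so shows that a larger group here does not by itself go with a lower number, a reading that compound 1 fits and compound 3 goes against. Isopropyl in place of pent-1-en-1-yl gives a 6.8-fold higher number from compound 1 to compound 3 (0.84 log units; beyond the scatter) and completes the picture so far: the two groups with a double bond outside aromatic rings, in compound 1 and compound 2, both stand at lower numbers than the isopropyl of compound 3, although three compounds are a narrow basis for any pattern. No supporting evidence is available to explain this rise at the carbonyl carbon.

The change from vinyl to isopropyl removes the double bond and introduces branching together, so the compounds shown cannot separate the two, and a straight saturated chain such as propyl or pentyl on the same carbonyl carbon would be needed to tell them apart. Also open, as far as these compounds go, is how a cyclopropyl group or a chain ending in an amine would compare with these three.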